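The compounds below may be only part of what the source reports. "The series", "measured", "known", "first", "only" and "open" are said of these compounds alone.

Measured so far:
compound 1, `COc1ccc2c(c1)c(-c1nc3ccccc3n1C(=O)c1ccccc1)cn2C`: 38400 nM
compound 2, `COc1cccc(C(=O)n2c(-c3cn(C)c4ccc(OC)cc34)nc3ccccc32)c1`: 14600 nM
compound 3, `COc1ccc(C(=O)n2c(-c3cn(C)c4ccc(Br)cc34)nc3ccccc32)cc1OC`: 11300 nM

All three were tested in a functional assay on MCF7 cells (Homo sapiens) for inhibition, read by MTT assay, with a stated time of 24 h; a lower number here means a stronger inhibitor of growth, a higher number a weaker inhibitor of growth. Compound 1 gives 38400 nM. Compound 2 differs from compound 1 by methoxy in place of hydrogen on an aromatic carbon, which brought a 2.6-fold lower number from compound 1 to compound 2 (0.42 log units; beyond the scatter). Compound 3 gives 11300 nM, a gap to compound 2 within the scatter and a gap to compound 1 beyond it; how the core of compound 3 differs from that of compound 1 is not broken down here. Compound 4, `COc1cc(C(=O)n2c(-c3cn(C)c4ccc(Br)cc34)nc3ccccc32)cc(OC)c1OC`, is not yet measured. It differs from compound 3 by methoxy in place of hydrogen on an aromatic carbon, the same kind of change as from compound 1 to compound 2, but the place is now also ortho to a methoxy group and meta to a methoxy group, not only meta to a large group. Among the compounds with values here, a somewhat smaller step of a 1.6-fold lower number from compound 3 to compound 4 (0.21 log units; within the scatter) is expected, because the one measured step of this kind is a 2.6-fold lower number from compound 1 to compound 2 (0.42 log units; beyond the scatter) and the surroundings of the place are not the same. Compound 4 is therefore estimated at 7000 nM, with a likely range from 2500 nM to 20000 nM.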

Compound 4, concentration for 50% growth inhibition: 9700 nM
Compound 4: middle estimate off by 1.4-fold (0.14 log units), on the low side, and the stated range covers the measured number.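

In this assay, adding one more methoxy group gave a 1.2-fold lower number from compound 3 to compound 4 (0.07 log units; within the scatter), a step too small to tell apart from repeat-to-repeat variation. Set beside the earlier step, the same change does not measurably differ between the two cores: the same change on two cores in this assay, a 2.6-fold lower number (0.42 log units; beyond the scatter) from compound 1 to compound 2 and a 1.2-fold lower number (0.07 log units; within the scatter) from compound 3 to compound 4, 2.3-fold (0.35 log units) apart, within the scatter of two such steps. This fits a methoxy step that carries over from one core to the other, but two steps, one of them within the scatter and each in different surroundings on the ring, cannot show that its size is the same across the series.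

The compounds shown leave open whether a different group at this place, such as an amine or a carboxylic acid, would shift the number more than methoxy does.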